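Removing One Thiazole Methyl in a Trimethoxyphenyl Series

This account rests on a few compounds, and the source may have more. Where it says the series, first, only, none or still open, it means among the compounds named here.

Compound 1 `C#CCSc1nc(Sc2nc3ccccc3s2)c(C#N)c(-c2cc(OC)c(OC)c(OC)c2)n1` is reported in a functional assay on PC-3 cells (Homo sapiens) for antiproliferative activity, read by MTT assay, with a stated time of 72 h (on this read-out lower numbers stand for stronger inhibition and higher numbers for weaker inhibition), only as the limit > 20000 nM.
Compound 2 `C#CCSc1nc(Sc2nc(C)c(C)s2)c(C#N)c(-c2cc(OC)c(OC)c(OC)c2)n1` is reported in this assay only as the limit > 20000 nM.
Compound 3 `C#CCSc1nc(Sc2nccs2)c(C#N)c(-c2ccc(Cl)cc2)n1` gives in this assay 3620 nM.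

Compound 2 stands at the limit of this assay, and it is one of the two values that sit there (the limit of > 20000 nM in this assay, at which 2 of the 3 values shown sit). The step that the two limits leave unreadable from compound 1 to compound 2 cannot be read, since both ends of it are limits. Compound 4 `C#CCSc1nc(Sc2nc(C)cs2)c(C#N)c(-c2cc(OC)c(OC)c(OC)c2)n1` differs from compound 2 in one place: hydrogen in place of methyl on an aromatic carbon. Going by the values given here, no measured step matches this change exactly. Among the compounds with values here, compound 3 carries an unsubstituted thiazole, but it also has a different aryl group, so its value and that of compound 2 show only that one compound is measurable and the other is not, with no single change between them. With no readable step bearing on the change, there is no ground for expecting a move beyond the scatter in this assay in either direction. The expected step that the limit leaves unreadable from compound 2 to compound 4 is therefore close to none, and compound 4 is estimated at 25000 nM, within a range of 8000 nM to 70000 nM, most likely again as a limit.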

Compound 4, half-maximal inhibitory concentration: > 20000 nM
Compound 4 was reported as a limit; the forecaster's own chance of this, stated with the estimate: 65%; the middle value lies beyond the limit too.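

Compound 4 is reported in this assay only as a limit, > 20000 nM. Its steps from compound 1 and from compound 2 cannot be read, as both ends of each are limits: the limit of > 20000 nM in this assay, at which 3 of the 4 values shown sit.

The compounds shown leave open whether hydrogen in place of methyl on an aromatic carbon changes activity in this assay at all.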